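Pyrrole in place of bromothiophene on the carbonyl

This account rests on a few compounds, and the source may have more. Where it says the series, first, only, none or still open, it means among the compounds named here.

The measured compounds:
compound 1 `COc1ccc(C(=O)/C=C/c2nc3ccccc3cc2-c2ccc(OC)cc2)cc1` gives 7540 nM in a functional assay on MDA-MB-231 cells (Homo sapiens) for antiproliferative activity, read by XTT assay, with a stated time of 72 h; a higher number here means a weaker inhibitor, a lower number a stronger inhibitor
compound 2 `COc1ccc(-c2cc3ccccc3nc2/C=C/C(=O)c2cccs2)cc1` gives 410 nM in this assay
compound 3 `COc1ccc(-c2cc3ccccc3nc2/C=C/C(=O)c2ccc(Br)s2)cc1` gives < 100 nM in this assay, which is a limit, not a number

Compound 3 stands at the strong end of the three: its reading is the limit of < 100 nM in this assay, at which 1 of the 3 values shown sits, and the steps of an at least 75-fold lower number from compound 1 to compound 3 (1.87 log units; beyond the scatter) and an at least 4.1-fold lower number from compound 2 to compound 3 (0.61 log units; beyond the scatter) both lie beyond the scatter, so it is the strongest inhibitor among the compounds shown.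

Compound 4 `COc1ccc(-c2cc3ccccc3nc2/C=C/C(=O)c2ccc[nH]2)cc1` differs from compound 3 in one place: 1H-pyrrol-2-yl in place of 5-bromothiophen-2-yl on a carbonyl carbon. Going by the values given here, two measured steps bear on this. The step of an at least 4.1-fold lower number from compound 2 to compound 3 (0.61 log units; beyond the scatter) shows that the bromo on the thiophene ring carries weight, and compound 4 has no bromo. The step of an 18-fold lower number from compound 1 to compound 2 (1.26 log units; beyond the scatter) shows that the identity of the ring on the carbonyl carbon itself moves the number strongly, and a pyrrole ring has not been measured here, so its effect is uncertain. The loss of the bromo is expected to weaken compound 4 relative to compound 3, by a step estimated as an at least 6.0-fold higher number from compound 3 to compound 4 (0.77 log units; beyond the scatter). Compound 4 is therefore estimated at 600 nM, with a range from 150 nM to 3000 nM.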

Compound 4, half-maximal inhibitory concentration: > 10000 nM
Compound 4: no number, only a limit (the forecaster's own chance of this, stated with the estimate: 10%); at least 16-fold (1.22 log units) between middle value and limit.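

In this assay compound 4 gives > 10000 nM, which is a limit of the assay and not a number. The earlier compounds shown here showed a thiophene ring on this carbonyl carbon doing far better than 4-methoxyphenyl, but a five-membered aromatic ring with one hetero atom proves not to be enough, as an at least 100-fold higher number from compound 3 to compound 4 (2.00 log units; beyond the scatter) and an at least 24-fold higher number from compound 2 to compound 4 (1.38 log units; beyond the scatter) show for the change to 1H-pyrrol-2-yl. The step of an at least 1.3-fold higher number from compound 1 to compound 4 (0.12 log units; that floor lies within the scatter) sets no order between the pyrrole and the 4-methoxyphenyl compound.

The compounds shown leave open whether the loss follows the hydrogen on the pyrrole nitrogen or the ring itself, which a pyrrole bearing methyl on that nitrogen, or a furan ring, would help to separate. They also leave open whether a bromo on the pyrrole ring would bring back any of the lost strength.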